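This account rests on a few compounds, and the source may have more. Where it says the series, first, only, none or still open, it means among the compounds named here.

Working notes on the series.

The shared core of compound 1 `Cc1nnc(SCC(=O)N/N=c2/scc(-c3ccc(C#N)cc3)n2-c2ccccc2)s1` carries a nitrile on one aryl ring; compound 2 `Cc1nnc(SCC(=O)N/N=c2/scc(-c3ccc([N+](=O)[O-])cc3)n2-c2ccccc2)s1` carries a nitro group there and compound 3 `COc1ccc(-c2cs/c(=N/NC(=O)CSc3nnc(C)s3)n2-c2ccccc2)cc1` a methoxy group. In a functional assay on C6 cells (Rattus norvegicus) for cytotoxicity, read by MTT assay, with a stated time of 24 h (a lower number here means a stronger inhibitor, a higher number a weaker inhibitor), compound 3 gives 18.7 ug/mL. In this assay compound 1 gives "not determined" (no result reported), and compound 2 gives "not determined" (no result reported), so neither of them has a value to stand on. For the measured compounds named here, the only figure available for the whole set is therefore the one from compound 3, and compound 1 cannot be placed relative to it.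

Compound 4 `Cn1nnnc1SCC(=O)N/N=c1/scc(-c2ccc(C#N)cc2)n1-c1ccccc1` keeps the core of compound 1 and differs from it in one place: 1-methyl-1H-tetrazol-5-yl in place of 5-methyl-1,3,4-thiadiazol-2-yl on a sulfur. Going by the values given here, no measured pair shows what such a swap does in this assay, so no step size can be read off. With nothing pointing in either direction, the expectation is a step of no more than the usual scatter from whatever compound 1 would have given, and in the absence of that figure the estimate leans on compound 3 as the only anchor. For compound 4 in this assay the estimate is 20 ug/mL, with a range from 7 ug/mL to 60 ug/mL.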

Compound 4, half-maximal inhibitory concentration: 23.3 ug/mL
Compound 4: the middle estimate sits 1.2-fold (0.07 log units) below what was measured, within the range that was stated.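

No new step can be read from compound 4, as compound 1, its one-place partner, has no single number in this assay. The compounds shown leave open what replacing 5-methyl-1,3,4-thiadiazol-2-yl with 1-methyl-1H-tetrazol-5-yl does in this assay, and how nitrile, nitro and methoxy compare on the shared core. No other data shown bear on this result.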